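Changing the Substituted Phenyl on the Ring Amine Nitrogen

This account rests on a few compounds, and the source may have more. Where it says the series, first, only, none or still open, it means among the compounds named here.

Compound 1, `Nc1scc(CN2CCN(c3cccc(C(F)(F)F)c3)CC2)c1C(=O)c1ccc(Cl)cc1`: -8.2%
Compound 2, `Nc1scc(CN2CCN(c3ccccc3C(F)(F)F)CC2)c1C(=O)c1ccc(Cl)cc1`: 0%
Compound 3, `Nc1scc(CN2CCN(c3ccc(OC(F)(F)F)cc3)CC2)c1C(=O)c1ccc(Cl)cc1`: not yet measured

In a functional assay on CHO cells with adenosine receptor A1 (Homo sapiens) as the target, read by cAMP accumulation and immunoassay, with a stated time of 6 min, tested at 0.01 uM (a lower number here means a stronger effect, a higher number a weaker effect of the compound at the concentration tested), compound 2 stands highest of the two numbers, with compound 1 as its nearest neighbour. Going by the values given here, the only step measured so far, a number 8.2 percentage points higher from compound 1 to compound 2 (within the scatter), lies within the scatter, so the two compounds cannot be told apart on this read-out. Compound 3 arises from compound 2 by 4-(trifluoromethoxy)phenyl in place of 2-(trifluoromethyl)phenyl on an amine nitrogen in a ring. That measured step bears on this change only loosely: it shifted the position of one trifluoromethyl group, whereas here a different group enters the same place, and it gave no movement beyond the scatter. With nothing in the data pointing either way, a step of a number 2 percentage points lower from compound 2 to compound 3 (within the scatter) is expected, that is none beyond the scatter. Compound 3 is therefore estimated at -2%, with a range from -14% to 10%.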

Compound 3, a percentage reported as activity, at one concentration (the size of the read-out at that concentration, not a potency): 0%
Estimate against measurement, compound 3: 2 percentage points below, and the stated range covers the measured number.
By their numbers in this assay, from the lowest: compounds 1, 2 and 3 (each within the scatter of the next).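

In this assay the exchange of 2-(trifluoromethyl)phenyl for 4-(trifluoromethoxy)phenyl gave no change at the digits printed from compound 2 to compound 3 (within the scatter), so a different group carrying an oxygen and a hydrogen-bond acceptor, and not only a shifted trifluoromethyl, can stand on this amine nitrogen in a ring without a movement beyond the scatter. Measured against 3-(trifluoromethyl)phenyl, the same group gave a number 8.2 percentage points higher from compound 1 to compound 3 (within the scatter), which leaves all three substituted phenyl groups indistinguishable on this read-out. Nothing available accounts for this lack of separation.

Going by these compounds, whether a phenyl carrying an amine or a carboxylic acid, or a longer alkyl chain in place of the phenyl, would move the number at this position stays open. Also open, on these data alone, is whether these three compounds would separate at another concentration.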